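The source may hold more compounds than are shown below. What is called first, only, known or untested is meant among the compounds shown, and "the series" means these compounds.

Among the compounds with values here, in a functional assay on a cell-free system (plasma, Homo sapiens) for inhibition, with Plasma (Rattus norvegicus) as the target (on this read-out lower numbers stand for stronger inhibition and higher numbers for weaker inhibition), compound 1 `Cc1c(OCc2cccnc2)ccc2c(N3CCNCC3)cc(=O)oc12` gives 980 nM, the lowest of the numbers measured so far, and compound 2 `O=c1cc(N2CCNCC2)c2cc(OCc3cccnc3)ccc2o1` gives 38000 nM, a gap well beyond the scatter. Compound 3 `CSCOc1ccc2c(N3CCNCC3)cc(=O)oc2c1C` has not yet been measured. It departs from compound 1 by methylsulfanyl in place of pyridin-3-yl on a saturated chain carbon bound to an oxygen on an aromatic ring, so methylsulfanyl replaces pyridin-3-yl on a saturated chain carbon bound to an oxygen on an aromatic ring. Within the data shown here, no measured pair shows this change, so only a moderate rise in this assay, beyond the scatter, is expected, and with little certainty. The expected move is a 3.1-fold higher number from compound 1 to compound 3 (0.49 log units; beyond the scatter). For compound 3 the estimate is 3000 nM, with an expected range of 700 nM to 13000 nM.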

Compound 3, half-maximal inhibitory concentration: 900 nM
Compound 3: the middle estimate sits 3.3-fold (0.52 log units) above what was measured; low and high end bracket the measured number.
By their numbers in this assay, from the lowest: compounds 3 and 1 (each within the scatter of the next); then compound 2.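

In this assay, methylsulfanyl in place of pyridin-3-yl gives a 1.1-fold lower number from compound 1 to compound 3 (0.04 log units; within the scatter). On this saturated chain carbon bound to an oxygen on an aromatic ring, the pyridine ring is therefore not required to hold the number, and a group with no ring and fewer heavy atoms serves equally well. Nothing at hand explains this tolerance. From the compounds shown here alone, whether an amine, a carboxylic acid or a longer chain would be tolerated in the same place remains open. So does whether methylsulfanyl would give the same result on the core of compound 2.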